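A few compounds are considered here, and "the series" means these few. Any claim that something is new, unique, unknown or untested is made for them only; others in the source may bear on it.

Compound 1 `CNC(=O)c1cc(C(=O)NCCCC2CNCCO2)cn(Cc2ccccc2)c1=O` and compound 2 `CNC(=O)c1cc(C(=O)NC2CC2)cn(Cc2nccc3[nH]ccc23)c1=O` have each been measured in a physicochemical assay for lipophilicity, at pH 7.4; on this read-out higher numbers stand for higher lipophilicity and lower numbers for lower lipophilicity. Compound 1 gives 1.4. Compound 2 gives 1.7, the higher of the two numbers, though the gap to compound 1 lies within the usual scatter of such measurements. Compound 3 `CNC(=O)c1cc(C(=O)NC2CC2)cn(Cc2cccc3cc[nH]c23)c1=O` has not been measured. It differs from compound 2 by a group of 9 heavy atoms (8 carbon, 1 nitrogen; one five-membered aromatic ring with 1 hetero atom, one six-membered aromatic ring of carbon only) in place of a group of 9 heavy atoms (7 carbon, 2 nitrogen; one five-membered aromatic ring with 1 hetero atom, one six-membered aromatic ring with 1 hetero atom), on a saturated chain carbon bound to an aromatic nitrogen. Among the measured compounds shown here, no measured pair shows this change directly. Taken from compound 2, a moderate rise in this assay is expected, by about a number 0.70 log units higher from compound 2 to compound 3 (beyond the scatter). Compound 3 is therefore estimated at 2.4, with a likely range from 1.9 to 3.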

Compound 3, distribution coefficient: 3.7
Estimate against measurement, compound 3: 1.30 log units below, outside the stated range (above it).
By their numbers in this assay, from the lowest: compounds 1 and 2 (each within the scatter of the next); then compound 3.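

Among the compounds shown here, at this position, on a saturated chain carbon bound to an aromatic nitrogen, swapping one ring nitrogen for carbon while keeping the same count of heavy atoms is enough to shift this assay by a large amount: 1H-indol-7-yl gives a number 2.00 log units higher from compound 2 to compound 3 (beyond the scatter) and is the first direct read of this change. So this place on the shared core responds strongly to a small edit of the attached group. Nothing available accounts for the size of this step.

From the compounds shown here alone, it remains open whether an amine or a carboxylic acid on the 1H-indol-7-yl group would bring the number back towards that of compound 2. Going by these compounds, it is also open whether the step would keep its size with a different amide on the core.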